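Swapping trifluoromethyl for chloro on the urea aryl ring

The source may report more compounds than this note shows. Statements on the series, on what has been measured and on what is new or still open speak of the compounds shown alone.

Measured so far:
compound 1 `COc1cc2cc(Oc3ccc(NC(=O)Nc4cccc(C(F)(F)F)c4)cc3)c(C)nc2cc1OC`: 1550 nM
compound 2 `COc1cc2cc(Oc3ccc(NC(=O)Nc4ccc(Cl)c(C(F)(F)F)c4)cc3)c(C)nc2cc1OC`: 1140 nM

In a functional assay on MOLT-4 cells (Homo sapiens) for inhibition, read by sulforhodamine B assay, with a stated time of 48 h (on this read-out lower numbers stand for stronger inhibition of growth and higher numbers for weaker inhibition of growth), compound 1 gives 1550 nM, while compound 2 gives 1140 nM. The two numbers sit close together, since a 1.4-fold lower number from compound 1 to compound 2 (0.13 log units; within the scatter), so compound 2 stands beside compound 1 rather than apart from it. Compound 3 `COc1cc2cc(Oc3ccc(NC(=O)Nc4ccc(Cl)c(Cl)c4)cc3)c(C)nc2cc1OC` differs from compound 2 in one place: chloro in place of trifluoromethyl on an aromatic carbon. Going by the values given here, no measured step covers this exchange; the single step recorded concerns a different change and was small. The expected step is therefore one that stays within the scatter, a 1.1-fold higher number from compound 2 to compound 3 (0.06 log units; within the scatter). Compound 3 is estimated to give 1300 nM, with a likely range from 600 nM to 2800 nM.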

Compound 3, concentration for 50% growth inhibition: 3020 nM
Estimate against measurement, compound 3: 2.3-fold (0.37 log units) below; the whole stated range lies below it.
By their numbers in this assay, from the lowest: compounds 2, 1 and 3 (each within the scatter of the next, the first and the last beyond it).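

Trifluoromethyl and chloro are not interchangeable at this position on the ring: in this assay, the exchange gives a 2.6-fold higher number from compound 2 to compound 3 (0.42 log units; beyond the scatter) and so weakens growth inhibition. Set against the simpler aryl group of compound 1, however, the 3,4-dichlorophenyl group gives a 1.9-fold higher number from compound 1 to compound 3 (0.29 log units; within the scatter) and so stands level with it. No measurement at hand explains the difference between trifluoromethyl and chloro. The compounds shown leave open how a nitrile, a methoxy group or an amine would behave at this position.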